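Dihydroxybenzyl isomers on a shared core

This account rests on a few compounds, and the source may have more. Where it says the series, first, only, none or still open, it means among the compounds named here.

Compound 1 `Cc1cc(-c2c(F)cc3c(=O)ccn(C4CC4)c3c2F)cc(C)n1` sets the baseline: in a functional assay on P388 cells (Mus musculus) for cytotoxicity (on this read-out higher numbers stand for weaker inhibition and lower numbers for stronger inhibition), compound 1 gives 15000 nM. Compound 2 `COc1ccccc1Cc1cn(C2CC2)c2c(F)c(-c3cc(C)nc(C)c3)c(F)cc2c1=O`, with a 2-methoxybenzyl group in place of hydrogen on an aromatic carbon, gives 37000 nM, a modest step of a 2.5-fold higher number from compound 1 to compound 2 (0.39 log units; beyond the scatter). Compound 3 `Cc1cc(-c2c(F)cc3c(=O)c(Cc4cccc(O)c4O)cn(C4CC4)c3c2F)cc(C)n1`, carrying 2,3-dihydroxybenzyl there instead, gives 880 nM, the lowest of the three numbers and clearly apart from both others.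

Compound 4 `Cc1cc(-c2c(F)cc3c(=O)c(Cc4cc(O)ccc4O)cn(C4CC4)c3c2F)cc(C)n1` has not yet been measured. It has 2,5-dihydroxyphenyl in place of 2,3-dihydroxyphenyl on a saturated chain carbon bound to an aromatic carbon.

Two large steps bear on this change: a 17-fold lower number from compound 1 to compound 3 (1.23 log units; beyond the scatter) and a 42-fold lower number from compound 2 to compound 3 (1.62 log units; beyond the scatter). Both lead to the 2,3-dihydroxybenzyl group from a group without that pattern, and compound 4 retains a dihydroxybenzyl group. Going by the values given here, neither step compares one dihydroxy arrangement with another, and the series holds no such pair, so the size of this change is poorly defined. Only a small step is expected in this assay, with no firm direction. The expected step is a 1.1-fold lower number from compound 3 to compound 4 (0.04 log units; within the scatter). The estimate for compound 4 is 800 nM, with an expected range of 250 nM to 3000 nM.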

Compound 4, half-maximal inhibitory concentration: 360 nM
For compound 4 the middle estimate is 2.2-fold (0.35 log units) above the measured one; low and high end bracket the measured number.
By their numbers in this assay, from the lowest: compound 4; then compound 3; then compound 1; then compound 2.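

The series now holds a direct comparison of two dihydroxy arrangements: in this assay, 2,5-dihydroxyphenyl in place of 2,3-dihydroxyphenyl gives a 2.4-fold lower number from compound 3 to compound 4 (0.39 log units; beyond the scatter) with the same atoms joined differently, so the arrangement of the two hydroxyl groups registers at this position, though only modestly. Both dihydroxybenzyl isomers now reach well below the hydrogen of the shared core, with a 42-fold lower number from compound 1 to compound 4 (1.62 log units; beyond the scatter) as the larger of the two drops, and the contrast with the 2-methoxybenzyl group widens to a 100-fold lower number from compound 2 to compound 4 (2.01 log units; beyond the scatter) at the same place. Going by these compounds alone, compound 2 remains the exception to any reading in which a substituted benzyl group alone lowers the number: it is the one benzyl compound that sits above compound 1.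

As far as these compounds go, whether both hydroxyl groups are required stays open, as does the reading for a 2-hydroxybenzyl, a 3,4-dihydroxybenzyl or a 2,5-dimethoxybenzyl group here, or for a carboxylic acid or an amine on the benzyl group in place of a hydroxyl. No supporting data are available to account for the difference between the two isomers.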